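Swapping One Halogen on a Cell-Killing Compound

The compounds below may be only part of what the source reports. "The series", "measured", "known", "first", "only" and "open" are said of these compounds alone.

In a functional assay on HeLa cells (Homo sapiens) for cytotoxicity, read by MTT assay, with a stated time of 72 h (on this read-out higher numbers stand for weaker inhibition and lower numbers for stronger inhibition), compound 1 (`Cn1ccc2c(Oc3ccc(NC(=O)c4cc5cccnc5n(-c5ccc(Cl)cc5)c4=O)cc3F)ncnc21`) gives 43900 nM. Compound 2 (`O=C(Nc1ccc(Oc2ncnc3[nH]ccc23)c(F)c1)c1cc2cccnc2n(-c2ccc(F)cc2)c1=O`) gives 3720 nM, the lower of the two numbers, with a gap beyond the scatter. Compound 3 (`O=C(Nc1ccc(Oc2ncnc3[nH]ccc23)c(F)c1)c1cc2cccnc2n(-c2ccc(Cl)cc2)c1=O`) is still unmeasured. It puts chloro in place of fluoro on an aromatic carbon, turning 4-fluorophenyl into 4-chlorophenyl: chloro in place of fluoro on an aromatic carbon. Within the data shown here, no measured pair shows this change alone, so the expectation is cautious: no step beyond the scatter, in either direction. The estimated move is a 1.2-fold higher number from compound 2 to compound 3 (0.08 log units; within the scatter). For compound 3 the expected value is 4500 nM, within a range of 1500 nM to 14000 nM.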

Compound 3, half-maximal inhibitory concentration: 23900 nM
Beside the measured number, compound 3's estimate is 5.3-fold (0.73 log units) below it, outside the stated range (above it).
By their numbers in this assay, from the lowest: compound 2; then compounds 3 and 1 (each within the scatter of the next).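

Among these compounds, at this position the halogen counts: in this assay, chloro in place of fluoro gives a 6.4-fold higher number from compound 2 to compound 3 (0.81 log units; beyond the scatter) and so lies beyond the scatter, even though only one atom changes. Hydrogen in place of methyl on an aromatic nitrogen gives a 1.8-fold lower number from compound 1 to compound 3 (0.26 log units; within the scatter) and stays within the scatter. Nothing measured here offers a reason for the halogen step.

Open, as far as these compounds go, is how a bromo, methoxy or amino group would read at this place. Also open, from the compounds shown here alone, is whether fluoro in place of chloro on compound 1 would give a similar step.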